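Cyanoguanidine series: a shorter branch on the chain

The source may report more compounds than this note shows. Statements on the series, on what has been measured and on what is new or still open speak of the compounds shown alone.

The series is read in an in vitro functional assay on Sf9 cells for antagonist activity at histamine H2 receptor (Homo sapiens); a higher number here means a more potent compound, by a factor of ten per unit of this negative logarithm, a lower number a less potent compound. Compound 1 `N#C/N=C(/NCCCc1c[nH]cn1)NCCCC1CCCCC1` gives only a limit there, < 5; < 5 (2 entries), with no single number behind it. Compound 2 `N#C/N=C(/NCCCCc1c[nH]cn1)NCCCC1CCCCC1` likewise stops at the limit < 5 in this assay. Compound 3 `CC(CCN/C(=N\C#N)NCCCCc1c[nH]cn1)c1ccccc1` also returns a limit, < 5. Among the compounds with values here, the one step between measured neighbours, a step that the two limits leave unreadable from compound 2 to compound 3, therefore cannot be read in either direction. Compound 2 thus stands at the limit alongside the other two, and no numbered value exists anywhere in the set; the shared floor is the limit of < 5 in this assay, at which 2 of the 3 values shown sit.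

Compound 4 `CC(C)CN/C(=N\C#N)NCCCCc1c[nH]cn1` is the next change from compound 2: isopropyl in place of 2-cyclohexylethyl on a saturated chain carbon bound to an amine nitrogen. Within the data shown here, no measured step bears on this change with a readable size, since the only step available, a step that the two limits leave unreadable from compound 2 to compound 3, is itself unreadable, and the evidence gives no direction for the new substituent either.

Among the measured compounds shown here, with every value so far a limit, the working expectation is that compound 4 also sits at the limit, so the expected step that the limit leaves unreadable from compound 2 to compound 4 is taken as none beyond the scatter. Compound 4 is accordingly estimated at 4.5, within 3.5 to 5.3, and most likely reported again only as a limit rather than a number.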

Compound 4, negative logarithm of the antagonist equilibrium constant: < 5
Compound 4: a limit, no number; the forecaster's own chance of this, stated with the estimate: 80%; the middle value does not contradict the limit.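

Compound 4 in this assay returns < 5, a limit and not a number. Compound 2 also stands only at a limit, so the step from compound 2 to compound 4 cannot be read. The compounds shown leave open whether any substituent on the shared core gives a numbered value, and the set stays at its floor: the limit of < 5 in this assay, at which 3 of the 4 values shown sit.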